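This account rests on a few compounds, and the source may have more. Where it says the series, first, only, none or still open, it means among the compounds named here.

Measured so far:
- Compound 1, `COc1ccccc1C1CC(C)=NN1C(=O)C[N+]1(C)CCCC1`: 11200 nM
- Compound 2, `O=C(CCl)N1N=C(c2cc3ccccc3oc2=O)CC1c1ccccc1`: 2980 nM

Both compounds were tested in a functional assay on PC-3 cells (Homo sapiens) for cytotoxicity, read by MTT assay, with a stated time of 48 h; a higher number here means a weaker inhibitor, a lower number a stronger inhibitor. Compound 1 gives 11200 nM. Compound 2 gives 2980 nM, the lowest of the two numbers; the gap between it and compound 1 lies beyond the usual scatter of repeated measurements.

The next compound, compound 3, has the structure `O=C(CNC1CC1)N1N=C(c2cc3ccccc3oc2=O)CC1c1ccccc1`. Relative to compound 2 the change is cyclopropylamino in place of chloro on a saturated chain carbon bound to a carbonyl carbon. Among the compounds with values here, both compounds share the same core; only this group on the saturated chain carbon bound to the carbonyl carbon differs.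

Within the data shown here, no pair of measured compounds differs by this kind of change, so there is no measured step to lean on. A modest step toward a higher number, perhaps not beyond the scatter, is expected, and compound 3 is estimated at 6000 nM in this assay, with a likely range from 1500 nM to 25000 nM, which corresponds to an expected step of a 2.0-fold higher number from compound 2 to compound 3 (0.30 log units; within the scatter).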

Compound 3, half-maximal inhibitory concentration: 28500 nM
Beside the measured number, compound 3's estimate is 4.8-fold (0.68 log units) below it; measured number outside the range, above it.
By their numbers in this assay, from the lowest: compound 2; then compound 1; then compound 3.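

In this assay, putting cyclopropylamino in place of chloro on the saturated chain carbon bound to the carbonyl carbon brings a 9.6-fold higher number from compound 2 to compound 3 (0.98 log units; beyond the scatter), so compound 3 is a clearly weaker inhibitor than compound 2. With the shared core unchanged, this shows that the result is sensitive to the group at this position, and that this exchange costs potency rather than leaving it intact. Nothing available here explains the rise, or says whether losing chloro or gaining cyclopropylamino matters more.

A single exchange cannot separate the part played by the amine nitrogen from that of the three-membered ring. A simple amino group, a dimethylamino group or a morpholine at this position would help to tell these apart.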